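The source may hold more compounds than are shown below. What is called first, only, known or untested is meant among the compounds shown, and "the series" means these compounds.

Two measured members of the series frame the question. Compound 1 `COCO[C@@H]1/C=C(\C)CC[C@]2([C@@](C)(O)C(=O)SCc3oc(=O)oc3C)CC(=O)N([C@H](C)c3nc(cs3)/C=C/C=C/C1=O)[S+]2[O-]` gives 0.17 nM in a functional assay on HeLa cells (Homo sapiens) for antiproliferative activity; a higher number here means a weaker inhibitor, a lower number a stronger inhibitor. Compound 2 `C/C1=C\[C@@H](O)C(=O)/C=C/C=C/c2csc(n2)[C@@H](C)N2C(=O)C[C@@]([C@@](C)(O)C(=O)SCC(=O)OC(C)(C)C)(CC1)[S+]2[O-]` gives 2.6 nM in this assay, the higher of the two numbers recorded so far; the gap to compound 1 lies beyond the scatter, but the two differ in several parts of the structure at once, so nothing can be attributed to any single change between them.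

Compound 3 `CCOC(=O)CSC(=O)[C@](C)(O)[C@@]12CC/C(C)=C/[C@@H](O)C(=O)/C=C/C=C/c3csc(n3)[C@@H](C)N(C(=O)C1)[S+]2[O-]` has not been measured. It differs from compound 2 in one place only: ethyl in place of tert-butyl on an oxygen next to a carbonyl group. Among the compounds with values here, the ester sits at the end of the thioester side chain, away from the shared core; ethyl in place of tert-butyl on an oxygen next to a carbonyl group is a small exchange of one alkyl group for a shorter one, and no measured pair isolates such a change. The expectation is therefore a step from compound 2 to compound 3 of about a 1.2-fold higher number from compound 2 to compound 3 (0.06 log units; within the scatter), that is, none beyond the scatter in either direction. For compound 3 the value expected in this assay is 3 nM, within the range 1 nM to 9 nM.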

Compound 3, half-maximal inhibitory concentration: 1300 nM
For compound 3 the middle estimate is 430-fold (2.64 log units) below the measured one; measured number above the stated range.
By their numbers in this assay, from the lowest: compound 1; then compound 2; then compound 3.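

Within the data shown here, this is the first pair that differs in one place only, and it shows that this position is far from silent in this assay: ethyl in place of tert-butyl, on an oxygen next to a carbonyl group, gives a 500-fold higher number from compound 2 to compound 3 (2.70 log units; beyond the scatter). The step is large even though the exchange is confined to one alkyl group, with the same difference reading (tert-butoxycarbonyl)methyl to (ethoxycarbonyl)methyl when cut further out, and no hydrogen-bond donor, hydrogen-bond acceptor, ring or net charge is counted on either group. Nothing available on these compounds bears on the reason for a step of this size.

Open, on these data alone, is whether the number climbs in order as the alkyl group shortens from tert-butyl to ethyl or whether tert-butyl alone holds a special place, a question that an isopropyl group, a methyl group or a free carboxylic acid on this oxygen would help to settle. Also open, as far as these compounds go, is whether the same exchange gives a step of similar size on the remainder of compound 1, whose side chain and other parts differ from those of compound 2 at once.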